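A Second Methyl on Compound 2

A few compounds are considered here, and "the series" means these few. Any claim that something is new, unique, unknown or untested is made for them only; others in the source may bear on it.

In a functional assay on the whole organism with Canis familiaris (Canis lupus familiaris) as the target (on this read-out higher numbers stand for an effect only at larger amounts of compound and lower numbers for an effect already at smaller amounts), compound 1 (`c1ccc(-c2nc3cc[nH]cc-3n2)cc1`) gives 2.5 mg/kg, and compound 2 (`Cc1cccc(-c2nc3cc[nH]cc-3n2)c1`) gives 1 mg/kg. Going by the values given here, compound 2 therefore holds the lower of the two numbers so far. Compound 3 (`Cc1ccc(-c2nc3cc[nH]cc-3n2)cc1C`) extends compound 2 by one further substitution: methyl in place of hydrogen on an aromatic carbon. Among the compounds with values here, only one measured step bears on this change. It is a 2.5-fold lower number from compound 1 to compound 2 (0.40 log units; beyond the scatter), a modest step beyond the scatter that also places a methyl on an aromatic carbon. Within the data shown here, no measured compound carries a methyl ortho to a methyl group, so this single step offers only limited guidance. A smaller move in the same direction seems most likely, and the estimate is a 1.3-fold lower number from compound 2 to compound 3 (0.10 log units; within the scatter). For compound 3 the expected value is 0.8 mg/kg, with an estimated range of 0.3 mg/kg to 2.5 mg/kg.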

Compound 3, dose for half-maximal effect: 5.2 mg/kg
Compound 3: middle estimate off by 6.5-fold (0.81 log units), on the low side; the measured number lies above the stated range.
By their numbers in this assay, from the lowest: compound 2; then compound 1; then compound 3.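

In this assay, methyl in place of hydrogen on an aromatic carbon does not act in one direction. The added methyl, ortho to a methyl group and para to a group of 9 heavy atoms, gives a 5.2-fold higher number from compound 2 to compound 3 (0.72 log units; beyond the scatter), whereas the earlier methyl gave a 2.5-fold lower number from compound 1 to compound 2 (0.40 log units; beyond the scatter), so the same exchange goes with opposite changes, both beyond the scatter, at two places on the six-membered aromatic ring. No measurement at hand accounts for this reversal.

From the compounds shown here alone, it remains open whether a methyl at this place would give the same rise without the methyl already present in compound 2. Going by these compounds, it also remains open whether a different group here, such as a chlorine, a methoxy or an amine, would follow the methyl or part from it.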